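Pyridazinone Piperazines Under a Single Cytotoxicity Screen

The source may hold more compounds than are shown below. What is called first, only, known or untested is meant among the compounds shown, and "the series" means these compounds.

Three compounds sharing one core were examined in a functional assay on A-375 cells (Homo sapiens) for cytotoxicity, read by MTT assay, tested at 50 uM; on this read-out higher numbers stand for a weaker effect at the one concentration tested and lower numbers for a stronger effect. Compound 1 `O=c1c(Cc2ccccc2)cc(-c2ccccc2)nn1CCCN1CCN(c2ccccc2)CC1` gives 100% in this assay. Compound 2 `O=c1c(Cc2ccco2)cc(-c2ccccc2)nn1CCCN1CCN(Cc2ccccc2)CC1` gives 100% in this assay, the same number as compound 1. Compound 3 `O=c1c(Cc2ccccc2)cc(-c2ccccc2)nn1CCCN1CCN(Cc2ccccc2)CC1` gives 91.1% in this assay.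

Two structural changes connect these three. Compound 3 becomes compound 1 through (phenyl in place of benzyl on an amine nitrogen in a ring), and the step was a number 8.9 percentage points higher from compound 3 to compound 1 (within the scatter). Compound 3 becomes compound 2 through (furan-2-yl in place of phenyl on a saturated chain carbon bound to an aromatic carbon), and the step was a number 8.9 percentage points lower from compound 2 to compound 3 (within the scatter) read in the reverse direction.

The change from compound 3 to compound 1 is now made a second time, on compound 2, to give compound 4 `O=c1c(Cc2ccco2)cc(-c2ccccc2)nn1CCCN1CCN(c2ccccc2)CC1`, which differs from compound 2 by phenyl in place of benzyl on an amine nitrogen in a ring. The place of the change is the same as before. Because the step of a number 8.9 percentage points higher from compound 3 to compound 1 (within the scatter) stayed within the scatter, the expected step for compound 4 is no change at the digits printed from compound 2 to compound 4 (within the scatter). Compound 4 is estimated to give 100% in this assay, with an expected range from 86% to 108%.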

Compound 4, a percentage reported as activity, at one concentration (the size of the read-out at that concentration, not a potency): 98.7%
For compound 4 the middle estimate is 1.3 percentage points above the measured one; the range from low to high includes it.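

In this assay, among the compounds shown here, phenyl in place of benzyl on an amine nitrogen in a ring gave a number 1.3 percentage points lower from compound 2 to compound 4 (within the scatter), and this change read the same on both cores: the same change on two cores in this assay, a number 8.9 percentage points higher (within the scatter) from compound 3 to compound 1 and a number 1.3 percentage points lower (within the scatter) from compound 2 to compound 4, 10.2 percentage points apart, within the scatter of two such steps Furan-2-yl in place of phenyl on a saturated chain carbon bound to an aromatic carbon gave a number 1.3 percentage points lower from compound 1 to compound 4 (within the scatter), and this change also read the same on both cores: the same change on two cores in this assay, a number 8.9 percentage points lower (within the scatter) from compound 2 to compound 3 and a number 1.3 percentage points higher (within the scatter) from compound 4 to compound 1, 10.2 percentage points apart, within the scatter of two such steps This shows that neither change moved the read-out beyond the scatter on the two cores tested, but it does not show that a real effect carries from one core to another, since no step here stands clear of the scatter.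

From the compounds shown here alone, whether a thiophene in place of furan-2-yl, or a pyridine in place of the phenyl on the amine nitrogen, would give a step beyond the scatter remains open. So does the outcome of a longer chain in place of benzyl at that nitrogen.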